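This account rests on a few compounds, and the source may have more. Where it says the series, first, only, none or still open, it means among the compounds named here.

Measured so far in a functional assay on liver (Sus scrofa) for inhibition of squalene monooxygenase (Homo sapiens), using microsomes; on this read-out lower numbers stand for stronger inhibition and higher numbers for weaker inhibition:
compound 1, `CCN(C/C=C/C#CC(C)(C)C)Cc1cccc(OC[Si](C)(C)c2ccc(Cl)cc2)c1`, gives 400 nM
compound 2, `CCN(C/C=C/C#CC(C)(C)C)Cc1cccc(OC[Si](C)(C)c2cccc(C)c2)c1`, gives 3000 nM
compound 3, `CCN(C/C=C/C#CC(C)(C)C)Cc1cccc(OC[Si](C)(C)c2ccccc2C(F)(F)F)c1`, gives 70 nM

Compound 3 gives the lowest number of the three, with a 5.7-fold lower number from compound 1 to compound 3 (0.76 log units; beyond the scatter) and a 43-fold lower number from compound 2 to compound 3 (1.63 log units; beyond the scatter) both beyond the scatter. Compound 4, `CCN(C/C=C/C#CC(C)(C)C)Cc1cccc(OC[Si](C)(C)c2ccc(O)cc2)c1`, differs from compound 3 by 4-hydroxyphenyl in place of 2-(trifluoromethyl)phenyl on a silicon. Among the measured compounds shown here, the steps that bear on this change are those that alter the aryl group on the silicon: a 7.5-fold higher number from compound 1 to compound 2 (0.88 log units; beyond the scatter), a 5.7-fold lower number from compound 1 to compound 3 (0.76 log units; beyond the scatter) and a 43-fold lower number from compound 2 to compound 3 (1.63 log units; beyond the scatter). All three show that the aryl group matters strongly in this assay and that 2-(trifluoromethyl)phenyl gives the lowest number; 4-hydroxyphenyl has not been measured. For compound 4 a step of a 21-fold higher number from compound 3 to compound 4 (1.33 log units; beyond the scatter) is therefore expected, with wide uncertainty. The estimate for compound 4 in this assay is 1500 nM, between 300 nM and 8000 nM.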

Compound 4, half-maximal inhibitory concentration: 8000 nM
Estimate against measurement, compound 4: 5.3-fold (0.73 log units) below, within the range that was stated.
By their numbers in this assay, from the lowest: compound 3; then compound 1; then compound 2; then compound 4.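

On the silicon, 4-hydroxyphenyl gives the highest number of the four in this assay, with a 110-fold higher number from compound 3 to compound 4 (2.06 log units; beyond the scatter) and a 2.7-fold higher number from compound 2 to compound 4 (0.43 log units; beyond the scatter). Among the compounds shown here, the cleanest reading is the single exchange of chloro for hydroxy on an aromatic carbon, which gives a 20-fold higher number from compound 1 to compound 4 (1.30 log units; beyond the scatter), so this aryl position tolerates these two groups very differently. The data offer no measured explanation for this loss. Still open, going by these compounds, is how a methoxy or an amine on that aromatic carbon would compare with hydroxy and chloro. A single hydroxy result cannot show whether other groups carrying oxygen or nitrogen behave alike.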